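Phenyl for hydroxyalkyl on the ring nitrogen: working notes

A few compounds are considered here, and "the series" means these few. Any claim that something is new, unique, unknown or untested is made for them only; others in the source may bear on it.

Measured so far in a functional assay on HTB-54 cells (Homo sapiens) for cytotoxicity, read by MTT assay, with a stated time of 72 h; on this read-out lower numbers stand for stronger inhibition of growth and higher numbers for weaker inhibition of growth:
compound 1, `CSc1nc(NCCCc2ccccc2)c2ccccc2n1`: > 100000 nM, a limit of the assay rather than a number.
compound 2, `CSc1nc(NCCCCc2ccccc2)c2ccccc2n1`: > 100000 nM, likewise a limit of the assay.
compound 3, `CSc1nc(NCCCCCO)c2ccccc2n1`: 71400 nM, the only number in the set.

For the measured compounds named here, compound 3 thus holds the sole numeric reading in this assay; the other two values sit at the limit of > 100000 nM in this assay, at which 2 of the 3 values shown sit. Compound 4, `CSc1nc(Nc2ccccc2)c2ccccc2n1`, differs from compound 3 by phenyl in place of 5-hydroxypentyl on a nitrogen on an aromatic ring. The measured steps that bear on it are those in which a phenyl on the chain gave way to a hydroxyl-bearing group: an at least 1.4-fold lower number from compound 1 to compound 3 (0.14 log units; that floor lies within the scatter) and an at least 1.4-fold lower number from compound 2 to compound 3 (0.14 log units; that floor lies within the scatter). Both are floors set by the limit, and both floors lie within the scatter, so they give only a direction, towards lower numbers on removing the aromatic group, and no size. Going by the values given here, compound 4 runs that change in reverse and at the same time drops the saturated chain altogether, which no measured pair covers. The expected step is a 2.1-fold higher number from compound 3 to compound 4 (0.32 log units; beyond the scatter), most likely carrying compound 4 back to the limit. Compound 4 is estimated at 150000 nM, within 40000 nM to 600000 nM, with a real chance that only a limit is reported.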

Compound 4, concentration for total growth inhibition: > 100000 nM
Compound 4 gave a limit, no number; the forecaster's own chance of this, stated with the estimate: 65%; the middle value lies beyond the limit too.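

In this assay, the change from 5-hydroxypentyl to phenyl on a nitrogen on an aromatic ring gives an at least 1.4-fold higher number from compound 3 to compound 4 (0.14 log units; that floor lies within the scatter), which fixes a direction but no size. Compound 4 stands at > 100000 nM, a limit and not a number. Phenyl set directly on that nitrogen therefore reads like the phenyl-ended chains of compound 1 and compound 2, and compound 3 remains the only compound with a numeric reading: the limit of > 100000 nM in this assay, at which 3 of the 4 values shown sit.

On these data alone, it remains open whether the reading of compound 3, 71400 nM, depends on its hydroxyl or on the saturated chain itself, and a pentyl chain ending in an amine or a carboxylic acid would help separate the two. As far as these compounds go, the true size of the gap between compound 3 and the three limits also remains unknown.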